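Extending the chain of compound 2

The source may report more compounds than this note shows. Statements on the series, on what has been measured and on what is new or still open speak of the compounds shown alone.

Of the compounds shown here, two have been measured so far in a physicochemical assay for lipophilicity; a lower number here means a more polar compound, a higher number a more lipophilic compound. Compound 1 `CC(C)c1nc2ccccc2[nH]1` gives 2.41, and compound 2 `CCCCCc1nc2ccccc2[nH]1` gives 3.43. Compound 2 therefore stands as the higher of the two, with a gap to compound 1 that lies beyond the scatter. Compound 3 `CCCCCCc1nc2ccccc2[nH]1` is still unmeasured. Its structure differs from that of compound 2 by a single change: methyl in place of hydrogen on a saturated chain carbon, five bonds along the chain from an aromatic carbon. For the measured compounds named here, no measured pair isolates this change, so the expectation has no direct precedent here. A moderate rise in this assay is expected, probably beyond the scatter, with an estimated step of a number 0.52 log units higher from compound 2 to compound 3 (beyond the scatter). For compound 3 the estimated value is 3.95, with an expected range of 3.65 to 4.3.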

Compound 3, partition coefficient: 3.93
Compound 3: middle estimate off by 0.02 log units, on the high side; the range from low to high includes it.
By their numbers in this assay, from the lowest: compound 1; then compound 2; then compound 3.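

In this assay, methyl in place of hydrogen on a saturated chain carbon, five bonds along the chain from an aromatic carbon, gives a step of a number 0.50 log units higher from compound 2 to compound 3 (beyond the scatter). For the compounds shown here, this is the first pair that differs in one place, so the size of this single change at this position can now be read directly, whereas compound 1 and compound 2 offered no such reading. No available evidence accounts for the size of this step.

A single step cannot show whether a longer chain would repeat the same rise or whether the rise would level off. Going by these compounds, how an amine or a carboxylic acid in place of the methyl at this position would move the number also remains open.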